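From Dimethylamino to Fluoro on the Aromatic Ring

The source may report more compounds than this note shows. Statements on the series, on what has been measured and on what is new or still open speak of the compounds shown alone.

In a functional assay on HT-29 cells (Homo sapiens) for inhibition, with a stated time of 72 h (a higher number here means a weaker inhibitor, a lower number a stronger inhibitor), compound 1 (`COc1ccc(S(=O)(=O)N2CCc3cccc(-c4ccc(N)cc4)c32)cc1`) stands at 301 nM and compound 2 (`COc1ccc(S(=O)(=O)N2CCc3cccc(-c4ccco4)c32)cc1`) at 62.5 nM while compound 3 (`COc1ccc(S(=O)(=O)N2CCc3cccc(-c4ccc(N(C)C)cc4)c32)cc1`) reads 467 nM on the same scale. Compound 3 and compound 1 therefore sit within the scatter of each other, and both show higher numbers than compound 2.

Compound 4 (`COc1ccc(S(=O)(=O)N2CCc3cccc(-c4ccc(F)cc4)c32)cc1`) has not yet been measured. It has fluoro in place of dimethylamino on an aromatic carbon of a six-membered aromatic ring of carbon only, para to a large group.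

Going by the values given here, no measured compound carries fluoro, so no step speaks to this change directly. The closest evidence is a 1.6-fold higher number from compound 1 to compound 3 (0.19 log units; within the scatter) for a change in the same group. Replacing the whole aromatic group gave the larger steps: a 4.8-fold lower number from compound 1 to compound 2 (0.68 log units; beyond the scatter) and a 7.5-fold higher number from compound 2 to compound 3 (0.87 log units; beyond the scatter) in the series.

Among the compounds with values here, compound 4 keeps the six-membered ring and loses the nitrogen group of compound 3, and compound 2 (62.5 nM) is the only measured compound without a nitrogen group. A modest move toward a lower number is therefore expected, smaller than the steps involving compound 2. The estimate amounts to a 2.6-fold lower number from compound 3 to compound 4 (0.41 log units; beyond the scatter) as an expected change. In this assay compound 4 is expected to give 180 nM (estimated range 60 nM to 500 nM).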

Compound 4, half-maximal inhibitory concentration: 85.5 nM
The estimate for compound 4 lay 2.1-fold (0.32 log units) above the measured number; the range from low to high includes it.
By their numbers in this assay, from the lowest: compounds 2 and 4 (each within the scatter of the next); then compounds 1 and 3 (each within the scatter of the next).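

In this assay, the group para to a large group on the six-membered aromatic ring proves able to shift the number well beyond the scatter, with a 5.5-fold lower number from compound 3 to compound 4 (0.74 log units; beyond the scatter) and a 3.5-fold lower number from compound 1 to compound 4 (0.55 log units; beyond the scatter), whereas exchanging one nitrogen group for the other had given only a 1.6-fold higher number from compound 1 to compound 3 (0.19 log units; within the scatter). The earlier compounds left open whether the gap to compound 2 followed the loss of the six-membered ring or the loss of the nitrogen group; compound 4 keeps that ring and still shows a 1.4-fold higher number from compound 2 to compound 4 (0.14 log units; within the scatter), so among these compounds the gap goes with the nitrogen group rather than with the ring. Nothing in the data shown explains why these numbers differ.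

Going by these compounds, with only amino, dimethylamino and fluoro at this place, it remains open whether the result is particular to fluoro or would extend to a chlorine, a methoxy, a hydroxyl or a carboxylic acid. On these data alone, it also remains open whether a nitrogen group other than these two, such as an amide or a nitrile, would stay with compound 1 and compound 3 or move toward compound 4.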